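Methyl for Chloro, Tried Again on a Weak Compound

The source may report more compounds than this note shows. Statements on the series, on what has been measured and on what is new or still open speak of the compounds shown alone.

Measured so far in a functional assay on MCF7 cells (Homo sapiens) for inhibition, read by MTT assay, with a stated time of 72 h; a higher number here means a weaker inhibitor, a lower number a stronger inhibitor:
compound 1 `N#Cc1c(Nc2ccccc2Cl)nc(SCc2cn(Cc3ccccc3Cl)nn2)nc1-c1ccccc1`: 1950 nM
compound 2 `Cc1ccccc1Nc1nc(SCc2cn(Cc3ccccc3Cl)nn2)nc(-c2ccccc2)c1C#N`: 7950 nM
compound 3 `N#Cc1c(Nc2ccccc2F)nc(SCc2cn(Cc3ccc(Cl)cc3)nn2)nc1-c1ccccc1`: the assay reports only a limit, > 64000 nM

Compound 1 and compound 2 differ by methyl in place of chloro on an aromatic carbon. That swap gave a 4.1-fold higher number from compound 1 to compound 2 (0.61 log units; beyond the scatter), a step beyond the usual scatter and pointing toward weaker inhibition. Compound 4 `Cc1ccc(Cn2cc(CSc3nc(Nc4ccccc4F)c(C#N)c(-c4ccccc4)n3)nn2)cc1` is built from compound 3 by methyl in place of chloro on an aromatic carbon. This is the same kind of change, not the same one: in the measured pair the group sits ortho to a large group, in the new pair para to a large group, and the group moves from the amino-bearing ring to the benzyl ring. How the core of compound 3 differs from the core of compound 1 is not broken down here.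

Compound 3 already gives only a limit in this assay, (the limit of > 64000 nM in this assay, at which 1 of the 3 values shown sits). A change of this kind weakened inhibition in the one measured case, a 4.1-fold higher number from compound 1 to compound 2 (0.61 log units; beyond the scatter), so compound 4 is expected to stay at or beyond that limit. The step is estimated as a step that the limit leaves unreadable from compound 3 to compound 4. Compound 4 is estimated at 130000 nM, between 40000 nM and 400000 nM.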

Compound 4, half-maximal inhibitory concentration: > 64000 nM
Compound 4: only a limit was reported; the forecaster's own chance of this, stated with the estimate: 85%; the middle value lies beyond the limit too.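

In this assay compound 3 and compound 4 each give only a limit, so no step can be read between them: the limit of > 64000 nM in this assay, at which 2 of the 4 values shown sit.

The compounds shown leave open whether going from 4-chlorobenzyl to 4-methylbenzyl shifts inhibition in either direction, and whether the weakening seen between compound 1 and compound 2 also holds for compounds this weak.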